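This account rests on a few compounds, and the source may have more. Where it says the series, first, only, none or still open, it means among the compounds named here.

For the measured compounds named here, compound 3, whose structure is `O=C(O)/C(S)=C/c1ccccc1Br`, gives the highest of the three numbers so far in an assay on isolated protein for inhibition of Calpain-1 catalytic subunit (Sus scrofa), read by FRET (on this read-out higher numbers stand for weaker inhibition and lower numbers for stronger inhibition), namely 21000 nM. Its nearest neighbour is compound 1, `O=C(O)/C(S)=C/c1ccccc1Cl`, which in this assay gives 11900 nM; the step of a 1.8-fold higher number from compound 1 to compound 3 (0.25 log units; within the scatter) is the only one that bears on the change to come. Going by the values given here, compound 2, `O=C(O)/C(S)=C/c1ccc(Br)cc1`, gives 1500 nM in this assay, but no single-place step links it to compound 3. Compound 4, `O=C(O)/C(S)=C/c1ccccc1I`, is compound 3 with iodo in place of bromo on an aromatic carbon. Among the compounds with values here, because the one halogen exchange on record, a 1.8-fold higher number from compound 1 to compound 3 (0.25 log units; within the scatter), stayed within the scatter, compound 4 is expected to show no step beyond the scatter, at most a slight rise, as a 1.2-fold higher number from compound 3 to compound 4 (0.08 log units; within the scatter). Compound 4 is therefore estimated at 25000 nM, with a range from 10000 nM to 60000 nM.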

Compound 4, half-maximal inhibitory concentration: 29600 nM
Compound 4: the middle estimate sits 1.2-fold (0.07 log units) below what was measured; the measured number falls inside the stated range.
By their numbers in this assay, from the lowest: compound 2; then compounds 1, 3 and 4 (each within the scatter of the next, the first and the last beyond it).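

In this assay iodo in place of bromo gives a 1.4-fold higher number from compound 3 to compound 4 (0.15 log units; within the scatter) while iodo in place of chloro gives a 2.5-fold higher number from compound 1 to compound 4 (0.40 log units; beyond the scatter) on this same aromatic carbon. Each single exchange of neighbouring halogens on record stays small here, and only the chloro and iodo compounds, compound 1 and compound 4, separate, and then modestly. No evidence on hand accounts for this.

As far as these compounds go, whether fluoro would extend the series at this place stays open. So does whether a methoxy group or an amine on this carbon would fit the same order.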